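Indolylmethyl to Cyanobenzyl on a Chemokine Receptor Antagonist

The source may report more compounds than this note shows. Statements on the series, on what has been measured and on what is new or still open speak of the compounds shown alone.

Compound 1 `COc1ccc2nccc(C3CN(CC4CCN(Cc5cc6ccccc6[nH]5)CC4)C(=O)O3)c2c1`: in an in vitro functional assay on RBL cells for antagonist activity at C-C chemokine receptor type 8 (Homo sapiens), read by FLIPR and calcium flux (a higher number here means a weaker inhibitor, a lower number a stronger inhibitor), compound 1 gives only a limit, < 50200 nM.
Compound 2 `O=C1OC(c2ccnc3ccccc23)CN1C1CCN(Cc2cc3ccccc3[nH]2)CC1`: in this assay compound 2 gives 1000 nM.
Compound 3 `COc1ccc2nccc(C3CN(C4CCN(Cc5cc6ccccc6n5C)CC4)C(=O)O3)c2c1`: in this assay compound 3 gives 3160 nM.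

Of the two actual numbers, compound 3 carries the higher one, so it is the weaker inhibitor of that pair; the gap to compound 2 is wider than the usual scatter. Compound 2 differs from compound 3 in more than one place, so the two values only show where each stands. Compound 4 `COc1ccc2nccc(C3CN(C4CCN(Cc5ccc(C#N)cc5)CC4)C(=O)O3)c2c1` keeps the core of compound 3 and changes one part: 4-cyanophenyl in place of 1-methyl-1H-indol-2-yl on a saturated chain carbon bound to an amine nitrogen in a ring. Among the measured compounds shown here, no measured pair isolates this change, so its effect is unknown. A step of a 3.2-fold higher number from compound 3 to compound 4 (0.50 log units; beyond the scatter) toward a weaker inhibitor is expected. Compound 4 is estimated to give 10000 nM, within 2000 nM to 50000 nM.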

Compound 4, half-maximal inhibitory concentration: 12600 nM
Beside the measured number, compound 4's estimate is 1.3-fold (0.10 log units) below it, within the range that was stated.
By their numbers in this assay, from the lowest: compound 2; then compound 3; then compound 4.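

Putting 4-cyanophenyl in place of 1-methyl-1H-indol-2-yl on a saturated chain carbon bound to an amine nitrogen in a ring gives a 4.0-fold higher number from compound 3 to compound 4 (0.60 log units; beyond the scatter) in this assay. Among the compounds shown here, this is the first single change that can be read, and it shows that the inhibitor weakens when this group is swapped. Compound 1 gives only a limit, not a number: the limit of < 50200 nM in this assay, at which 1 of the 4 values shown sits.

Going by these compounds, it remains open whether the weakening follows the loss of 1-methyl-1H-indol-2-yl or the arrival of the nitrile. A plain benzyl group on the core of compound 3 would help separate the two.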